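The source may hold more compounds than are shown below. What is called first, only, known or untested is meant among the compounds shown, and "the series" means these compounds.

Measured compounds:
compound 1 `CC(=O)Nc1cccc(C2CCN(CCCn3c(-c4ccccc4Cl)nc4ccccc43)CC2)c1`, 10 nM
compound 2 `CC(=O)Nc1cccc(C2CCN(CCCn3c(-c4ccccc4C(F)(F)F)nc4ccccc43)CC2)c1`, 50 nM
compound 3 `CC(=O)Nc1cccc(C2CCN(CCCn3c(-c4ccc(F)cc4)nc4ccccc43)CC2)c1`, 56 nM

In an assay for displacement of a labelled ligand from melanin-concentrating hormone receptor 1 (Homo sapiens), read by fluorescence (on this read-out lower numbers stand for stronger inhibition and higher numbers for weaker inhibition), compound 3 gives the highest of the three numbers: its step from compound 1, a 5.6-fold higher number from compound 1 to compound 3 (0.75 log units; beyond the scatter), lies beyond the scatter, whereas a 1.1-fold higher number from compound 2 to compound 3 (0.05 log units; within the scatter) does not. Compound 4 `CC(=O)Nc1cccc(C2CCN(CCCn3c(-c4ccc(Br)cc4)nc4ccccc43)CC2)c1` differs from compound 3 by bromo in place of fluoro on an aromatic carbon, para to a large group. Among the compounds with values here, no measured step exchanges one halogen for another at this place; a 5.0-fold higher number from compound 1 to compound 2 (0.70 log units; beyond the scatter) and a 5.6-fold higher number from compound 1 to compound 3 (0.75 log units; beyond the scatter) each move the substituent on the ring as well as change it, so they bear only loosely on this change. Compound 4 is therefore expected to stay close to the number just described, a step of a 1.2-fold lower number from compound 3 to compound 4 (0.09 log units; within the scatter), not beyond the scatter. For compound 4 the estimate is 45 nM, within 15 nM to 150 nM.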

Compound 4, half-maximal inhibitory concentration: 5 nM
The estimate for compound 4 lay 9.0-fold (0.95 log units) above the measured number, and the stated range ends above it.
By their numbers in this assay, from the lowest: compounds 4 and 1 (each within the scatter of the next); then compounds 2 and 3 (each within the scatter of the next).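

In this assay, within the data shown here, the halogen at this place, para to a large group, turns out not to be interchangeable: an 11-fold lower number from compound 3 to compound 4 (1.05 log units; beyond the scatter) is the first step that exchanges one halogen for another there, and it is large. Likewise a 10-fold lower number from compound 2 to compound 4 (1.00 log units; beyond the scatter) lies beyond the scatter, while a 2.0-fold lower number from compound 1 to compound 4 (0.30 log units; within the scatter) stays within it, so 4-bromophenyl and the 2-chlorophenyl of compound 1 cannot be told apart here. Nothing available explains the difference between bromo and fluoro.

As far as these compounds go, whether chloro or iodo at this place would match bromo remains open, as does whether an amine or a methoxy group there would keep the number of compound 4.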